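Replacing the hydroxyethyl arm with phenyl on the amine nitrogen

The source may hold more compounds than are shown below. What is called first, only, known or untested is meant among the compounds shown, and "the series" means these compounds.

Compound 1 `OCCNCc1nc2c(OCC3CCCCC3)cccc2[nH]1` stands highest of the three compounds measured in an assay on cells for inhibition of interleukin-5 receptor subunit alpha (Mus musculus), read by WST assay, with a stated time of 48 h, tested at 30 uM, in the presence of a further agent that is not named here (on this read-out lower numbers stand for less inhibition and higher numbers for more inhibition at the one concentration tested (going by the name of the read-out)), giving 63.3%. Compound 2 `OCCCNCc1nc2c(OCC3CCCCC3)cccc2[nH]1` gives 52.7%, and compound 3 `c1ccc(CNCc2nc3c(OCC4CCCCC4)cccc3[nH]2)cc1` gives 49.3%. The steps of a number 10.6 percentage points lower from compound 1 to compound 2 (beyond the scatter) and a number 14 percentage points lower from compound 1 to compound 3 (beyond the scatter) were both modest losses, while the step of a number 3.4 percentage points lower from compound 2 to compound 3 (within the scatter) stayed within the scatter. Compound 4 `c1ccc(NCc2nc3c(OCC4CCCCC4)cccc3[nH]2)cc1` differs from compound 1 by phenyl in place of 2-hydroxyethyl on an amine nitrogen. The steps from compound 1 to compound 2 and to compound 3 bear on this change, as both remove the hydroxy group near the amine nitrogen and both cost a modest amount. A similar modest loss is therefore expected, so that compound 4 is estimated at 50%, with a range of 35% to 65%, a step of a number 13.3 percentage points lower from compound 1 to compound 4 (beyond the scatter).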

Compound 4, a percentage reported as inhibition, at one concentration (the size of the read-out at that concentration, not a potency): 25%
Compound 4: the middle estimate sits 25 percentage points above what was measured, outside the stated range (below it).
By their numbers in this assay, from the lowest: compound 4; then compounds 3 and 2 (each within the scatter of the next); then compound 1.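

Placing phenyl directly on the amine nitrogen in this assay gives a number 38.3 percentage points lower from compound 1 to compound 4 (beyond the scatter) as the only large step in the series, so this change costs more than the earlier changes to the chain did. Loss of the hydroxy group does not account for the whole drop: benzyl also lacks it, yet phenyl in its place gives a number 24.3 percentage points lower from compound 3 to compound 4 (beyond the scatter) as a further loss, and phenyl in place of 3-hydroxypropyl gives a number 27.7 percentage points lower from compound 2 to compound 4 (beyond the scatter) as well. Nothing available here explains this drop.

The compounds shown leave open how a plain ethyl group or a longer 2-phenylethyl chain on the amine nitrogen would read. They also leave open whether a hydroxy group or an amine on the phenyl ring would restore any of the lost inhibition.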